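The source may hold more compounds than are shown below. What is called first, only, known or untested is meant among the compounds shown, and "the series" means these compounds.

Of the compounds shown here, three that share one core have been measured in an ADME assay on L02 cells (Homo sapiens) for cytotoxicity, read by MTT assay, with a stated time of 24 h; on this read-out higher numbers stand for weaker inhibition and lower numbers for stronger inhibition. Compound 1 `Cc1ccc(S(=O)(=O)N2C/C(=C\c3ccccc3F)C(=O)/C(=C/c3ccccc3F)C2)cc1` gives 16700 nM in this assay. Compound 2 `CC(=O)Nc1ccc(S(=O)(=O)N2C/C(=C\c3ccccc3F)C(=O)/C(=C/c3ccccc3F)C2)cc1` gives 11500 nM. Compound 3 `O=C1/C(=C/c2cccc(F)c2)CN(S(=O)(=O)c2ccc(O[N+](=O)[O-])cc2)C/C1=C\c1cccc(F)c1` gives 10700 nM, the lowest of the three numbers, though its gaps to compound 2 and to compound 1 both fall within the scatter, so no order among the three can be read from them. Compound 4 `CC(=O)Nc1ccc(S(=O)(=O)N2C/C(=C\c3cccc(F)c3)C(=O)/C(=C/c3cccc(F)c3)C2)cc1` has not yet been measured. It differs from compound 3 by acetamido in place of nitrooxy on an aromatic carbon. Among the compounds with values here, no measured pair shows exactly this exchange. The nearest guide is the change from methyl to acetamido on an aromatic carbon, a 1.5-fold lower number from compound 1 to compound 2 (0.16 log units; within the scatter), which stayed within the scatter. Compound 2, which also carries acetamido, shows 11500 nM, close to what compound 3 shows. The expectation is therefore a step of no size beyond the scatter, a 1.1-fold higher number from compound 3 to compound 4 (0.03 log units; within the scatter). Compound 4 is estimated at 11500 nM in this assay, with a likely range from 6000 nM to 22000 nM.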

Compound 4, half-maximal inhibitory concentration: 17500 nM
Compound 4: the middle estimate sits 1.5-fold (0.18 log units) below what was measured; the range from low to high includes it.
By their numbers in this assay, from the lowest: compounds 3, 2, 1 and 4 (each within the scatter of the next).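

On the aromatic carbon para to a large group, acetamido in place of nitrooxy gives a step within the scatter (a 1.6-fold higher number from compound 3 to compound 4 (0.21 log units; within the scatter)) in this assay, and the fluorines here sit as they do in compound 3. Beside the earlier exchange of methyl for acetamido (a 1.5-fold lower number from compound 1 to compound 2 (0.16 log units; within the scatter)), this is a second exchange at this place that stays within the scatter, even though acetamido carries a hydrogen-bond donor and nitrooxy carries none. No measured evidence accounts for this result. The compounds shown leave open whether an amine or a carboxylic acid on this carbon would give a step beyond the scatter. A longer chain ending in either group, or plain hydrogen at this place, also remains an open case.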